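Two Aryl Groups and an Amide Chain on a Fused Core

A few compounds are considered here, and "the series" means these few. Any claim that something is new, unique, unknown or untested is made for them only; others in the source may bear on it.

Compound 1, `CNC(=O)c1cc(Oc2ccc(NC(=O)c3cc4cccnc4n(-c4ccc(F)c(Cl)c4)c3=O)cc2)ccn1`: 1810 nM
Compound 2, `CCCNC(=O)c1cc(Oc2ccc(NC(=O)c3cc4cccnc4n(-c4ccc(OC)cc4)c3=O)cc2)ccn1`: 1560 nM

In a functional assay on HT-29 cells (Homo sapiens) for antiproliferative activity, read by MTT assay, with a stated time of 72 h (on this read-out lower numbers stand for stronger inhibition and higher numbers for weaker inhibition), compound 2 gives 1560 nM and compound 1 gives 1810 nM; the two numbers lie within the usual scatter of each other, so the two compounds are not told apart here. Compound 3, `CCCNC(=O)c1cc(Oc2ccc(NC(=O)c3cc4cccnc4n(-c4ccc(F)c(Cl)c4)c3=O)cc2)ccn1`, is not yet measured; it differs from compound 2 by 3-chloro-4-fluorophenyl in place of 4-methoxyphenyl on an aromatic nitrogen. Among the measured compounds shown here, compound 1 already carries this aryl group, but with a different amide chain, so no single-change step is available to judge the swap. The step from compound 2 to compound 3 is expected to be small, a 1.0-fold lower number from compound 2 to compound 3 (0.02 log units; within the scatter), with no direction beyond the scatter. Compound 3 is estimated at 1500 nM, within 600 nM to 4000 nM.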

Compound 3, half-maximal inhibitory concentration: 920 nM
Compound 3: middle estimate off by 1.6-fold (0.21 log units), on the high side, and the stated range covers the measured number.
By their numbers in this assay, from the lowest: compounds 3, 2 and 1 (each within the scatter of the next).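

Among the compounds shown here, with the amide chain held the same, 3-chloro-4-fluorophenyl in place of 4-methoxyphenyl on the aromatic nitrogen gives a 1.7-fold lower number from compound 2 to compound 3 (0.23 log units; within the scatter) in this assay and so offers the first direct reading of this swap, which does not separate the two aryl groups. With the aryl group held the same, ethyl in place of hydrogen on the chain carbon bound to the amide-type nitrogen gives a 2.0-fold lower number from compound 1 to compound 3 (0.29 log units; within the scatter) and likewise separates nothing. No supporting measurement bears on either step.

As far as these compounds go, whether an amine, a carboxylic acid or a longer chain on the amide would shift the number beyond the scatter remains open.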